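This account rests on a few compounds, and the source may have more. Where it says the series, first, only, none or still open, it means among the compounds named here.

Compound 1 `CC(C)NC(=N)c1cccc(-c2cc3cc(C(=N)NC(C)C)ccc3o2)c1` was examined in an ADME assay on L6 cells (Rattus norvegicus) for cytotoxicity; a higher number here means a weaker inhibitor, a lower number a stronger inhibitor. In this assay compound 1 gives only a limit, > 199000 nM, which is the limit of > 199000 nM in this assay, at which 1 of the 3 values shown sits. Compound 3 `COc1ccc(C(=N)NC(C)C)cc1-c1cc2cc(C(=N)NC(C)C)ccc2o1` likewise gives only a limit, > 179000 nM, which is the limit of > 179000 nM in this assay, at which 1 of the 3 values shown sits. The step from compound 1 to compound 3, a step that the two limits leave unreadable from compound 1 to compound 3, is methoxy in place of hydrogen on an aromatic carbon. For the measured compounds named here, compound 2 `c1cc(C2=NCCN2)cc(-c2cc3cc(C4=NCCN4)ccc3o2)c1` supplies the single number, 33900 nM; how its core differs from that of compound 1 is not broken down here. Compound 4 `COc1ccc(C2=NCCN2)cc1-c1cc2cc(C3=NCCN3)ccc2o1` carries the same kind of change, (methoxy in place of hydrogen on an aromatic carbon), with the place differing in being para to a group of 5 heavy atoms rather than 6. The measured step left its size unreadable. The step from compound 2 to compound 4 is expected to be a 1.2-fold higher number from compound 2 to compound 4 (0.07 log units; within the scatter). Compound 4 is expected to give about 40000 nM, between 12000 nM and 150000 nM.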

Compound 4, half-maximal inhibitory concentration: 30800 nM
Estimate against measurement, compound 4: 1.3-fold (0.11 log units) above; low and high end bracket the measured number.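

In this assay, methoxy in place of hydrogen on an aromatic carbon gives a 1.1-fold lower number from compound 2 to compound 4 (0.04 log units; within the scatter), so on the core of compound 2 the two numbers cannot be told apart. The same change on the core of compound 1 cannot be read, as both compounds of that step give only limits, so the series offers one readable step and does not show that the change carries from one core to the other. Nothing measured here accounts for the result.

The compounds shown leave open how an amine, a carboxylic acid or a longer chain such as ethoxy would read on the same aromatic carbon. They also leave open whether any such group would give a readable number on the core of compound 1.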